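Benzimidazole in place of pyridine on a piperazine nitrogen

A few compounds are considered here, and "the series" means these few. Any claim that something is new, unique, unknown or untested is made for them only; others in the source may bear on it.

Measured compounds:
Compound 1 `COc1cccc(C(=O)CCCN2CCN(c3ccccc3OC)CC2)c1`, in an assay on isolated protein for binding affinity to 5-hydroxytryptamine receptor 7 (Rattus norvegicus) (on this read-out higher numbers stand for weaker inhibition and lower numbers for stronger inhibition), compound 1 gives 109 nM.
Compound 2 `O=C(CCCCCN1CCN(c2ccccn2)CC1)c1ccccc1O`, in this assay compound 2 gives 105 nM.

Within the data shown here, only two compounds have been measured, and no step between them has been worked out. Compound 2 holds the lowest of the two numbers, but its nearest neighbour, compound 1, sits within the scatter, so the two values show no order between them.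

The next compound, compound 3 `O=C(CCCCCN1CCN(c2nc3ccccc3[nH]2)CC1)c1ccccc1O`, is built from compound 2 by one change on the amine nitrogen in the ring of the shared core: 1H-benzimidazol-2-yl in place of pyridin-2-yl on an amine nitrogen in a ring. No measured step covers this kind of change, so nothing among the shown values tells how the larger bicyclic group will behave in this assay.

The expectation is therefore cautious: no step beyond the scatter in either direction, with some allowance for a weaker number given the larger group. For compound 3 the estimated value in this assay is 150 nM, with a range from 40 nM to 600 nM, which means an expected step of a 1.4-fold higher number from compound 2 to compound 3 (0.15 log units; within the scatter).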

Compound 3, inhibition constant: 682 nM
The estimate for compound 3 lay 4.5-fold (0.66 log units) below the measured number; measured number above the stated range.
By their numbers in this assay, from the lowest: compounds 2 and 1 (each within the scatter of the next); then compound 3.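

In this assay, the first step read at this position goes against the larger group: 1H-benzimidazol-2-yl in place of pyridin-2-yl on the amine nitrogen in the ring gives a 6.5-fold higher number from compound 2 to compound 3 (0.81 log units; beyond the scatter), beyond the scatter. This shows that the read-out responds to what this nitrogen carries, even with the rest of compound 2 unchanged, and that the change to the entering group does not leave the number where it stood. That group differs in several ways at once, with a five-membered aromatic ring, a six-membered aromatic ring of carbon only and a hydrogen-bond donor that pyridin-2-yl lacks, and no measurement on hand accounts for the step.

Which of these differences matters stays open: a 1-methyl-1H-benzimidazol-2-yl group would keep both rings without the ring hydrogen, and a quinolin-2-yl group would offer a larger aromatic group with no such donor. Compound 1 differs from compound 3 in more than one place, so it cannot show whether the same change would have a similar effect on another chain or with another aryl ketone.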